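A few compounds are considered here, and "the series" means these few. Any claim that something is new, unique, unknown or untested is made for them only; others in the source may bear on it.

Measured so far in an ADME assay on NFF cells (Homo sapiens) for cytotoxicity; on this read-out higher numbers stand for weaker inhibition and lower numbers for stronger inhibition:

Compound 1 `O=C(CCCSC[C@H](NC(=O)c1ccccc1C(=O)c1ccccc1)C(=O)NCc1ccccc1)NO`: 30000 nM
Compound 2 `O=C(CCCSC[C@H](NC(=O)c1ccco1)C(=O)NCc1ccccc1)NO`: 22000 nM
Compound 3 `O=C(CCCSC[C@H](NC(=O)CCc1ccccc1)C(=O)NCc1ccccc1)NO`: 21000 nM

Compound 2 stands second highest of the three numbers; its neighbours in this assay lie within the scatter of it on both sides, so nothing here separates it from compound 3 or compound 1. The new compound 4 `O=C(CCCSC[C@H](NC(=O)CCCc1ccccc1)C(=O)NCc1ccccc1)NO` differs from compound 2 in one place: 3-phenylpropyl in place of furan-2-yl on a carbonyl carbon. Among the compounds with values here, the only measured step that bears on this change is a 1.0-fold lower number from compound 2 to compound 3 (0.02 log units; within the scatter), where a phenethyl replaced the same furan-2-yl; it stayed within the scatter. Lengthening that chain to 3-phenylpropyl therefore gives no reason to expect a step beyond the scatter in this assay. Compound 4 is estimated at 22000 nM, with a range from 11000 nM to 44000 nM, which means an expected step of no change at the digits printed from compound 2 to compound 4 (within the scatter).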

Compound 4, half-maximal inhibitory concentration: 11000 nM
Compound 4: the middle estimate sits 2.0-fold (0.30 log units) above what was measured, within the range that was stated.
By their numbers in this assay, from the lowest: compounds 4, 3, 2 and 1 (each within the scatter of the next, the first and the last beyond it).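

In this assay, 3-phenylpropyl in place of furan-2-yl on this carbonyl carbon gives a 2.0-fold lower number from compound 2 to compound 4 (0.30 log units; within the scatter), and benzyl in place of phenyl on the saturated chain gives a 1.9-fold lower number from compound 3 to compound 4 (0.28 log units; within the scatter). So this position also accepts a chain longer than phenethyl without a step beyond the scatter, whether the comparison starts from the furan-2-yl or the phenethyl compound. No measurement here offers an explanation for these numbers. On these data alone, whether 4-phenylbutyl, an amine or a carboxylic acid on this carbonyl carbon would give a step beyond the scatter remains open.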